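A Substituent Swap Carried Onto a Second Core

A few compounds are considered here, and "the series" means these few. Any claim that something is new, unique, unknown or untested is made for them only; others in the source may bear on it.

Measured compounds in a functional assay on ZR-75-1 cells (Homo sapiens) for inhibition, read by sulforhodamine B assay; a higher number here means a weaker inhibitor of growth, a lower number a stronger inhibitor of growth:
compound 1, `Cc1ccc2[nH]c(-c3ccc(-c4ccc(-c5ccc(N(C)C)cc5)cc4)cc3)nc2c1`, 7200 nM
compound 2, `Cc1ccc2[nH]c(-c3ccc(-c4ccc(-c5cccc(Cl)c5)cc4)cc3)nc2c1`, 3450 nM
compound 3, `CN(C)c1ccc(-c2ccc(-c3ccc(-c4nc5ccccc5[nH]4)cc3)cc2)cc1`, 100000 nM

Compounds 1 and 2 share one core and differ by 3-chlorophenyl in place of 4-(dimethylamino)phenyl on an aromatic carbon; in this assay this gives a 2.1-fold lower number from compound 1 to compound 2 (0.32 log units; beyond the scatter). Compound 3 carries a second core, which differs from the first by hydrogen in place of methyl on an aromatic carbon, and this alone gives a 14-fold higher number from compound 1 to compound 3 (1.14 log units; beyond the scatter), leaving compound 3 with the highest number of the three.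

Compound 4, `Clc1cccc(-c2ccc(-c3ccc(-c4nc5ccccc5[nH]4)cc3)cc2)c1`, is not yet measured. It differs from compound 3 by 3-chlorophenyl in place of 4-(dimethylamino)phenyl on an aromatic carbon, the same change as that from compound 1 to compound 2, made at the same kind of place. Within the data shown here, the step from compound 3 to compound 4 in this assay is therefore expected to be about a 2.0-fold lower number from compound 3 to compound 4 (0.30 log units; within the scatter), resting on a 2.1-fold lower number from compound 1 to compound 2 (0.32 log units; beyond the scatter) as the only observation of this change, while compound 3 already stands at a very high value. Compound 4 is estimated at 50000 nM, expected between 15000 nM and 150000 nM.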

Compound 4, concentration for 50% growth inhibition: 41200 nM
The estimate for compound 4 lay 1.2-fold (0.08 log units) above the measured number; low and high end bracket the measured number.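

In this assay, the swap from 4-(dimethylamino)phenyl to 3-chlorophenyl gives a 2.4-fold lower number from compound 3 to compound 4 (0.39 log units; beyond the scatter), so the change carries from the core of compound 1 to the core of compound 3 with its size preserved: the same change on two cores in this assay, a 2.1-fold lower number (0.32 log units; beyond the scatter) from compound 1 to compound 2 and a 2.4-fold lower number (0.39 log units; beyond the scatter) from compound 3 to compound 4, 1.2-fold (0.07 log units) apart, within the scatter of two such steps. Read the other way round, the loss of the methyl group gives a 12-fold higher number from compound 2 to compound 4 (1.08 log units; beyond the scatter), and this step also holds with either group in place: the same change on two cores in this assay, a 14-fold higher number (1.14 log units; beyond the scatter) from compound 1 to compound 3 and a 12-fold higher number (1.08 log units; beyond the scatter) from compound 2 to compound 4, 1.2-fold (0.07 log units) apart, within the scatter of two such steps. Across these four compounds the two changes therefore act independently of each other, but this rests on one pair of groups and one pair of cores, and it shows neither why they do so nor that other groups would carry over in the same way.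

On these data alone, it remains open whether the same holds for other groups in place of the 3-chlorophenyl, such as an amine or a carboxylic acid. Also open, as far as these compounds go, is what an ethyl or a methoxy group would do in place of the methyl group on the core of compound 1.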